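Anilide aryl swaps in a dimethoxy-indanone amide series

This account rests on a few compounds, and the source may have more. Where it says the series, first, only, none or still open, it means among the compounds named here.

Compound 1 `COc1ccc(NC(=O)C2Cc3cc(OC)c(OC)cc3C2=O)cc1` stands lowest of the three measured numbers in a physicochemical assay for lipophilicity, read by mass spectrometry (a lower number here means a more polar compound, a higher number a more lipophilic compound), where compound 1 gives 2.08. Compound 2 `COc1cc2c(cc1OC)C(=O)C(C(=O)Nc1ccc(F)cc1)C2` gives 2.36 in this assay, and compound 3 `COc1cc2c(cc1OC)C(=O)C(C(=O)Nc1ccc(Cl)cc1)C2` gives 2.76. Among the steps, a number 0.28 log units higher from compound 1 to compound 2 (within the scatter) and a number 0.68 log units higher from compound 1 to compound 3 (beyond the scatter); the remaining step, a number 0.40 log units higher from compound 2 to compound 3 (beyond the scatter), lies between the two halogen anilides.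

Compound 4 `COc1cc2c(cc1OC)C(=O)C(C(=O)Nc1ccccc1C)C2` is not yet measured. Compared with compound 1 the change is 2-methylphenyl in place of 4-methoxyphenyl on an amide-type nitrogen. For the measured compounds named here, no measured step replaces the methoxy group with a methyl group, so the halogen steps are the nearest guide: removing the methoxy group for a fluoro gave a step within the scatter, removing it for a chloro gave a modest step upward. A step of similar kind, upward and of modest size, is therefore expected here, since the change likewise removes the one hydrogen-bond acceptor of the leaving group; the expected step is a number 0.52 log units higher from compound 1 to compound 4 (beyond the scatter). For compound 4 the estimate in this assay is 2.6, with a range from 2.25 to 2.95.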

Compound 4, partition coefficient: 2.69
The estimate for compound 4 lay 0.09 log units below the measured number; the measured number falls inside the stated range.
By their numbers in this assay, from the lowest: compounds 1 and 2 (each within the scatter of the next); then compounds 4 and 3 (each within the scatter of the next).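

In this assay the 2-methylphenyl group on the amide-type nitrogen gives a number 0.61 log units higher from compound 1 to compound 4 (beyond the scatter) and so shows that a replacement for 4-methoxyphenyl carrying no halogen can also move the number beyond the scatter. Set against the halogen anilides, the same group gives a number 0.07 log units lower from compound 3 to compound 4 (within the scatter) and a number 0.33 log units higher from compound 2 to compound 4 (beyond the scatter), which puts it level with 4-chlorophenyl and apart from 4-fluorophenyl. At this position, a ring substituent named at 2 therefore reads alongside those named at 4, although group and ring position change together in each of these steps.

The series leaves open whether the methyl group or its ring position sets this number, a question 4-methylphenyl would address. From the compounds shown here alone, how an amine or a carboxylic acid on this ring would read also remains open. No supporting measurement bears on why these steps take these sizes.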